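A few compounds are considered here, and "the series" means these few. Any claim that something is new, unique, unknown or untested is made for them only; others in the source may bear on it.

Of the compounds shown here, three have been measured in a functional assay on HepG2 cells (Homo sapiens) for antiproliferative activity, read by MTT assay, with a stated time of 72 h; on this read-out lower numbers stand for stronger inhibition and higher numbers for weaker inhibition. Compound 1 `NC1=NC2(CCSCC2)N(OCCCOc2ccc(Cl)cc2)C(N)=N1` gives 1100 nM; compound 2 `COc1ccc(OCCCON2C(N)=NC(N)=NC23CCSCC3)cc1` gives 880 nM; compound 3 `NC1=NC2(CCSCC2)N(OCCCOc2ccccc2Cl)C(N)=N1` gives 80 nM. Compound 3 stands lowest of the three numbers. Both steps that end at it lie beyond the scatter: an 11-fold lower number from compound 2 to compound 3 (1.04 log units; beyond the scatter) and a 14-fold lower number from compound 1 to compound 3 (1.14 log units; beyond the scatter). Among the measured compounds shown here, the one exchange of a substituent on an aromatic carbon recorded so far, a 1.3-fold lower number from compound 1 to compound 2 (0.10 log units; within the scatter), stayed within the scatter.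

Compound 4 `NC1=NC2(CCSCC2)N(OCCCOc2ccccc2Br)C(N)=N1` differs from compound 3 in a single place: bromo in place of chloro on an aromatic carbon. For the measured compounds named here, no measured pair tests bromo against chloro on an aromatic carbon. Going by the values given here, the two large steps exchange one whole aryl group for another rather than the halogen itself, and the one substituent exchange at a fixed place on the ring gave no movement beyond the scatter. Little change is therefore expected, no change at the digits printed from compound 3 to compound 4 (within the scatter), in no clear direction. Compound 4 is estimated at 80 nM in this assay, with a range from 35 nM to 180 nM.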

Compound 4, half-maximal inhibitory concentration: 90 nM
Beside the measured number, compound 4's estimate is 1.1-fold (0.05 log units) below it, within the range that was stated.
By their numbers in this assay, from the lowest: compounds 3 and 4 (each within the scatter of the next); then compounds 2 and 1 (each within the scatter of the next).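

In this assay, bromo and chloro on an aromatic carbon ortho to a large group are not told apart (a 1.1-fold higher number from compound 3 to compound 4 (0.05 log units; within the scatter)). The 2-bromophenyl group also stands apart from the 4-methoxyphenyl and 4-chlorophenyl groups (a 9.8-fold lower number from compound 2 to compound 4 (0.99 log units; beyond the scatter); a 12-fold lower number from compound 1 to compound 4 (1.09 log units; beyond the scatter)), so the low numbers no longer rest on the 2-chlorophenyl group of compound 3 alone. No evidence bearing on the origin of these numbers is at hand.

Open, going by these compounds, is whether the low numbers persist with fluoro, methyl, an amine or a carboxylic acid on the same aromatic carbon, or with no substituent there at all. Also open, on these data alone, is how a longer chain in the linker, in place of the present one, would read alongside the 2-chlorophenyl and 2-bromophenyl groups.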